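Chain extension on the core of compound 3

The source may hold more compounds than are shown below. What is called first, only, known or untested is meant among the compounds shown, and "the series" means these compounds.

Compound 3 `CCCc1cc2ccccc2nc1-c1cc(-c2ccccc2)no1` carries a propyl chain on the shared core. In a functional assay on PC-3 cells (Homo sapiens) for inhibition, read by MTT assay, with a stated time of 24 h (a lower number here means a stronger inhibitor, a higher number a weaker inhibitor), compound 3 gives 51300 nM, the highest of the two numbers shown. The nearest is compound 1 `Cc1ccc(-c2cc(/C=N/c3ccccc3)on2)cc1`, which in this assay gives 31600 nM, a gap that lies within the usual scatter. Compound 2 `CCc1cc2ccccc2nc1-c1cc(-c2ccccc2)no1`, the ethyl analogue, gives in this assay only a limit of the assay, > 100000 nM. Of the three values shown, one sits at the limit of > 100000 nM in this assay, at which 1 of the 3 values shown sits, so the lengthening step is known only as a floor: an at least 1.9-fold lower number from compound 2 to compound 3 (0.28 log units; that floor lies within the scatter). Within the data shown here, that is the single measured step that bears on chain length, and its floor sits within the scatter.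

Compound 4 `CCCCc1cc2ccccc2nc1-c1cc(-c2ccccc2)no1` is the next member of the chain: methyl in place of hydrogen on a saturated chain carbon, three bonds along the chain from an aromatic carbon. Among the measured compounds shown here, the one prior lengthening step gives no firm direction, so for compound 4 in this assay no shift beyond the scatter is expected, a 1.3-fold lower number from compound 3 to compound 4 (0.11 log units; within the scatter). Compound 4 is therefore estimated at 40000 nM, with a range from 15000 nM to 100000 nM.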

Compound 4, half-maximal inhibitory concentration: > 100000 nM
Compound 4 was reported as a limit; the forecaster's own chance of this, stated with the estimate: 25%; middle value at least 2.5-fold (0.39 log units) from the limit.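

Going from propyl to butyl at this position gives, in this assay, an at least 1.9-fold higher number from compound 3 to compound 4 (0.28 log units; that floor lies within the scatter). This floor points the opposite way to the earlier ethyl to propyl step, yet it stays within the scatter, and the step between compound 2 and compound 4 cannot be read, as both values are limits. So no direction with chain length can be read from these compounds, and the chain series leans heavily on a single assay limit: the limit of > 100000 nM in this assay, at which 2 of the 4 values shown sit.

From the compounds shown here alone, it remains open whether any chain on the shared core gives a number clearly beyond the scatter from compound 3. A longer chain such as hexyl, or an amine or a carboxylic acid at the end of the chain, could test this with values inside the range of the assay.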